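Replacing Cyclopropyl with Thiophenyl on the Thiophene Ring

The source may report more compounds than this note shows. Statements on the series, on what has been measured and on what is new or still open speak of the compounds shown alone.

Three compounds built on one shared core have been examined in an ADME assay on MDCK cells (Canis lupus familiaris) for cytotoxicity, read by microscopy, with a stated time of 48 h; on this read-out lower numbers stand for higher toxicity in this test and higher numbers for lower toxicity in this test. Compound 1 `Cc1ccsc1CN[C@@H]1C[C@H]2C[C@@H]([C@H]1C)C2(C)C` gives 10000 nM. Compound 2 `CCCc1ccsc1CN[C@@H]1C[C@H]2C[C@@H]([C@H]1C)C2(C)C` gives 50000 nM, and compound 3 `C[C@H]1[C@H](NCc2sccc2C2CC2)C[C@H]2C[C@@H]1C2(C)C` gives 25000 nM. Compound 3 therefore stands second highest of the three numbers: its nearest neighbour, compound 2, lies within the scatter of it, while the gap a 2.5-fold higher number from compound 1 to compound 3 (0.40 log units; beyond the scatter) is beyond the scatter.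

Compound 4 `C[C@H]1[C@H](NCc2sccc2-c2ccsc2)C[C@H]2C[C@@H]1C2(C)C` has not yet been measured. It differs from compound 3 by thiophen-3-yl in place of cyclopropyl on an aromatic carbon. Among the measured compounds shown here, the steps that bear on this change are the enlargements of the group on the aromatic carbon: a 5.0-fold higher number from compound 1 to compound 2 (0.70 log units; beyond the scatter) and a 2.5-fold higher number from compound 1 to compound 3 (0.40 log units; beyond the scatter), both modest rises, whereas a 2.0-fold lower number from compound 2 to compound 3 (0.30 log units; within the scatter) stayed within the scatter. Thiophen-3-yl is again a larger group than cyclopropyl, so a modest rise or no change beyond the scatter is expected in this assay, not a fall.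

For compound 4 the expected step is a 2.0-fold higher number from compound 3 to compound 4 (0.30 log units; within the scatter). Compound 4 is accordingly estimated to give 50000 nM, with a range from 20000 nM to 125000 nM.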

Compound 4, minimum cytotoxic concentration: 12500 nM
Estimate against measurement, compound 4: 4.0-fold (0.60 log units) above, outside the stated range (below it).
By their numbers in this assay, from the lowest: compounds 1, 4, 3 and 2 (each within the scatter of the next, the first and the last beyond it).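

In this assay, the step to the larger thiophen-3-yl, with 5 heavy atoms against 3 for cyclopropyl, on this aromatic carbon two ring bonds from the ring sulfur brings no rise beyond the scatter (a 2.0-fold lower number from compound 3 to compound 4 (0.30 log units; within the scatter)). Set against the other two groups, the aromatic ring stands apart from propyl (a 4.0-fold lower number from compound 2 to compound 4 (0.60 log units; beyond the scatter)) but not from methyl (a 1.3-fold higher number from compound 1 to compound 4 (0.10 log units; within the scatter)), which makes thiophen-3-yl the only one of the three replacements for methyl whose number stays within the scatter of compound 1, and compounds 2 and 3 show that a larger group at this position need not give the same result as compound 4. Nothing measured here accounts for this difference between the groups.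

The compounds shown leave open whether the ring sulfur of thiophen-3-yl has any part in this result, a question that phenyl or thiophen-2-yl at the same place could address. They also leave open how far the number would move with a longer chain such as butyl, or with an amine or a carboxylic acid at the end of the propyl chain.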